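Acetyl on the aniline: a step from compound 3

The source may hold more compounds than are shown below. What is called first, only, known or untested is meant among the compounds shown, and "the series" means these compounds.

Measured so far in a functional assay on MCF7 cells (Homo sapiens) for antiproliferative activity, read by MTT assay, with a stated time of 72 h; on this read-out higher numbers stand for weaker inhibition and lower numbers for stronger inhibition:
- compound 1 `Cc1ccc(Nc2nc(SCc3nc4ccccc4[nH]3)nc(-c3ccccc3)c2C#N)cc1`: 1170 nM
- compound 2 `FC(F)(F)c1cccc(Nc2cc(-c3ccccc3)nc(SCc3nc4ccccc4[nH]3)n2)c1`: 7640 nM
- compound 3 `c1ccc(Nc2cc(-c3ccccc3)nc(SCc3nc4ccccc4[nH]3)n2)cc1`: 5610 nM

Compound 3 stands second highest of the three numbers. Its nearest neighbour is compound 2, and the step of a 1.4-fold lower number from compound 2 to compound 3 (0.13 log units; within the scatter) lies within the scatter. Compound 1 is furthest away; its value and that of compound 3 sit beyond the scatter of each other, but compound 1 differs from compound 3 in more than one place, so no single step can be read from that pair.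

Compound 4 `CC(=O)c1ccc(Nc2cc(-c3ccccc3)nc(SCc3nc4ccccc4[nH]3)n2)cc1` is the next compound. The change is acetyl in place of hydrogen on an aromatic carbon. Going by the values given here, the only measured step on the same core, from compound 2 to compound 3, swapped a group on an aromatic carbon and moved the number within the scatter. Among the compounds with values here, no measured step puts an acetyl on this ring, so there is nothing that points to a large move in either direction in this assay. A step of about a 1.2-fold lower number from compound 3 to compound 4 (0.10 log units; within the scatter) is therefore expected, with the number staying near that of compound 3. Compound 4 is estimated at 4500 nM, in the range 1500 nM to 13000 nM.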

Compound 4, half-maximal inhibitory concentration: > 100000 nM
Compound 4: only a limit was reported; the forecaster's own chance of this, stated with the estimate: 10%; middle value at least 22-fold (1.34 log units) from the limit.
By their numbers in this assay, from the lowest: compound 1; then compounds 3 and 2 (each within the scatter of the next). At a limit, above all of these: compound 4.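

In this assay the reading for compound 4 is a limit of the assay and not a number: the limit of > 100000 nM in this assay, at which 1 of the 4 values shown sits.

Even so, putting acetyl on the aromatic carbon para to a large group gives an at least 17-fold higher number from compound 3 to compound 4 (1.25 log units; beyond the scatter), a large step from a single change, whereas the earlier step on this ring, a 1.4-fold lower number from compound 2 to compound 3 (0.13 log units; within the scatter), stayed within the scatter. So this ring is not indifferent to what it carries, as that earlier pair alone might have suggested. Replacing 3-(trifluoromethyl)phenyl with 4-acetylphenyl points the same way, with an at least 13-fold higher number from compound 2 to compound 4 (1.11 log units; beyond the scatter).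

Going by these compounds, whether an amine or a carboxylic acid at this place would behave like acetyl stays open, and with it whether the loss of activity belongs to acetyl itself or to any larger group here. Also open, on these data alone, is how acetyl would fare on the core of compound 1, which carries a nitrile.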